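Extending the acyl chain on compound 2

The source may hold more compounds than are shown below. What is called first, only, known or untested is meant among the compounds shown, and "the series" means these compounds.

Measured so far:
compound 1 `N#Cc1c(-c2ccccc2)cn(-c2ccc(S(=O)(=O)Nc3ccccn3)cc2)c1N`: 4600 nM
compound 2 `N#Cc1c(-c2ccccc2)cn(-c2ccc(S(=O)(=O)Nc3nccs3)cc2)c1NC(N)=O`: 8050 nM
compound 3 `N#Cc1c(-c2ccccc2)cn(-c2ccc(S(=O)(=O)Nc3ccccn3)cc2)c1NC(N)=O`: 7340 nM

All three were tested in a functional assay on MCF7 cells (Homo sapiens) for inhibition, read by sulforhodamine B assay, with a stated time of 24 h; on this read-out lower numbers stand for stronger inhibition and higher numbers for weaker inhibition. Compound 2 gives the highest number of the three, though its gaps to compound 3 and to compound 1 both lie within the scatter.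

Compound 4 `N#Cc1c(-c2ccccc2)cn(-c2ccc(S(=O)(=O)Nc3nccs3)cc2)c1NC(=O)CCC(=O)O` is not yet measured. It differs from compound 2 in one place: 2-carboxyethyl in place of amino on a carbonyl carbon. For the measured compounds named here, no measured pair shows this exact change. Going by the values given here, the only step on the same amide-type nitrogen, a 1.6-fold higher number from compound 1 to compound 3 (0.20 log units; within the scatter), stayed within the scatter, and a 1.1-fold lower number from compound 2 to compound 3 (0.04 log units; within the scatter) also moved little. No step beyond the scatter is therefore expected in this assay.

Compound 4 is estimated at 9000 nM, with a range of 3500 nM to 25000 nM, meaning an expected step of a 1.1-fold higher number from compound 2 to compound 4 (0.05 log units; within the scatter).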

Compound 4, half-maximal inhibitory concentration: 9120 nM
Estimate against measurement, compound 4: 1.0-fold (0.01 log units) below; the range from low to high includes it.
By their numbers in this assay, from the lowest: compounds 1, 3, 2 and 4 (each within the scatter of the next).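

On the carbonyl carbon whose other neighbour is the amide-type nitrogen, 2-carboxyethyl in place of amino gives a 1.1-fold higher number from compound 2 to compound 4 (0.05 log units; within the scatter) in this assay. The earlier steps shown here covered only adding carbamoyl to the nitrogen and changing the sulfonamide substituent, whereas this one shows that a chain ending in a carboxylic acid can replace the amino group without a step beyond the scatter. No evidence on why this replacement leaves the number within the scatter is available.

Open, going by these compounds, is whether an amine, a methyl ester or a longer chain on this carbonyl carbon would move the number beyond the scatter. Also open, on these data alone, is whether 2-carboxyethyl behaves the same with pyridin-2-yl on the sulfonamide nitrogen.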